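Aryl replacement on the oxadiazole series: compound 2 to compound 4

This account rests on a few compounds, and the source may have more. Where it says the series, first, only, none or still open, it means among the compounds named here.

The set holds three measured compounds and one awaiting measurement. Compound 1 `O=[N+]([O-])c1ccc(-c2nnc(C3CCc4cc(F)ccc4O3)o2)cc1` gives 28700 nM in a functional assay; on this read-out lower numbers stand for stronger inhibition and higher numbers for weaker inhibition. Compound 3 `Fc1ccc2c(c1)CCC(c1nnc(C3CCc4cc(F)ccc4O3)o1)O2` gives 29000 nM in this assay. Compound 2 `Fc1ccc2c(c1)CCC(c1nnc(-c3ccccc3Cl)o1)O2` gives 40800 nM in this assay, nominally the highest of the three numbers, but its gaps to compound 3 and to compound 1 both lie within the usual scatter, so no order among the three can be read. Compound 4 `Nc1ccc(-c2nnc(C3CCc4cc(F)ccc4O3)o2)cc1` is not yet measured. It differs from compound 2 in one place: 4-aminophenyl in place of 2-chlorophenyl on an aromatic carbon. Going by the values given here, no measured pair shows this change directly. The three measured compounds, carrying quite different groups, all fall in one narrow band, which gives no ground to expect a step beyond the scatter in either direction. The estimated step of a 1.4-fold lower number from compound 2 to compound 4 (0.13 log units; within the scatter) is accordingly a small one. Compound 4 is expected to give 30000 nM in this assay, with a range from 8000 nM to 120000 nM.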

Compound 4, half-maximal inhibitory concentration: 34900 nM
For compound 4 the middle estimate is 1.2-fold (0.07 log units) below the measured one, and the stated range covers the measured number.
By their numbers in this assay, from the lowest: compounds 1, 3, 4 and 2 (each within the scatter of the next).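

In this assay, going by these compounds alone, 4-aminophenyl in place of 2-chlorophenyl on this aromatic carbon gives a 1.2-fold lower number from compound 2 to compound 4 (0.07 log units; within the scatter), the first direct reading of this change, and it shows no difference that can be read. Amino in place of nitro on the aromatic ring gives a 1.2-fold higher number from compound 1 to compound 4 (0.08 log units; within the scatter), so the series now has one-place pairs at this group, and neither moves the number beyond the scatter. Nothing at hand bears on why these changes leave the read-out flat.

Every compound shown lies in one narrow band, so it remains open whether any group at this position can produce a step beyond the scatter. A carboxylic acid or piperidine in place of the aryl group would extend the comparison to groups of a different kind.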